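The source may hold more compounds than are shown below. What is called first, only, known or untested is meant among the compounds shown, and "the series" means these compounds.

Measured so far:
compound 1 `COc1cc(/C=C/C(=O)/C=C(/C=C/c2ccc(OC(C)=O)c(OC)c2)NC2CCCCC2)ccc1OC(C)=O` — 10100 nM
compound 2 `COc1cc(/C=C/C(=O)/C=C(/C=C/c2ccc(OC(C)=O)c(OC)c2)NCC(C)C)ccc1OC(C)=O` — a limit, see below
compound 3 `COc1cc(/C=C/C(=O)/C=C(/C=C/c2ccc(O)c(OC)c2)NC2CCCCC2)ccc1O` — 24700 nM

All three were read in a functional assay on CHO-K1 cells (Cricetulus griseus) for inhibition, read by MTT assay, with a stated time of 72 h; on this read-out higher numbers stand for weaker inhibition and lower numbers for stronger inhibition. Compound 1 gives 10100 nM. The change isobutyl in place of cyclohexyl on an amine nitrogen produces an at least 2.4-fold higher number from compound 1 to compound 2 (0.39 log units; beyond the scatter). For compound 2 the value, > 25000 nM, is a limit of the assay and not a number, one of those counted in the limit of > 25000 nM in this assay, at which 1 of the 3 values shown sits. Compound 3 stands at 24700 nM, the higher of the two numbers recorded; how its core differs from that of compound 1 is not broken down here.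

Compound 4 `COc1cc(/C=C/C(=O)/C=C(/C=C/c2ccc(O)c(OC)c2)NCC(C)C)ccc1O` has not yet been measured in this assay. It differs from compound 3 by isobutyl in place of cyclohexyl on an amine nitrogen, the same change as from compound 1 to compound 2, made at the same place. Given that compound 3 already sits at 24700 nM and that the earlier step was an at least 2.4-fold higher number from compound 1 to compound 2 (0.39 log units; beyond the scatter), the step from compound 3 to compound 4 is expected to come out near a 2.4-fold higher number from compound 3 to compound 4 (0.39 log units; beyond the scatter). Compound 4 is therefore estimated at about 60000 nM, within 25000 nM to 150000 nM, most likely reported only as a limit.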

Compound 4, half-maximal inhibitory concentration: > 25000 nM
Compound 4 was reported as a limit; the forecaster's own chance of this, stated with the estimate: 80%; the middle value does not contradict the limit.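

In this assay compound 4 gives > 25000 nM, a limit of the assay and not a number. Carrying isobutyl in place of cyclohexyl on an amine nitrogen to the core of compound 3 gives an at least 1.0-fold higher number from compound 3 to compound 4 (0.00 log units; that floor lies within the scatter), so this result does not contradict the higher number seen on the core of compound 1, but it does not show that a step of that size carries over. Set side by side, the two steps show the change on both cores, but they cannot be ranked: the same change on two cores in this assay, an at least 2.4-fold higher number (0.39 log units; beyond the scatter) from compound 1 to compound 2 and an at least 1.0-fold higher number (0.00 log units; that floor lies within the scatter) from compound 3 to compound 4; the limit leaves it open whether they differ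

How far compound 2 and compound 4 lie beyond the limit, and so the true size of each step, stays open: the limit of > 25000 nM in this assay, at which 2 of the 4 values shown sit. The compounds shown also leave open how a longer chain or a benzyl group in place of cyclohexyl on the amine nitrogen would read on either core.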